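A few compounds are considered here, and "the series" means these few. Any claim that something is new, unique, unknown or untested is made for them only; others in the source may bear on it.

Measured compounds:
compound 1, `COc1cc(Cc2nc3c(N)nc(F)nc3n2CC2CCCO2)cc(OC)c1OC`: 22900 nM
compound 2, `CC[C@H](C)Cn1c(Cc2cc(OC)c(OC)c(OC)c2)nc2c(N)nc(F)nc21`: 43700 nM
compound 3, `COc1cc(Cc2nc3c(N)ncnc3n2CC2CC2)cc(OC)c1OC`: 75900 nM

In a functional assay on MCF7 cells (Homo sapiens) for antiproliferative activity (on this read-out lower numbers stand for stronger inhibition and higher numbers for weaker inhibition), compound 3 differs from compound 1 by more than the scatter, while its gap to compound 2 lies within the scatter. Compound 4, `CC/C=C\Cn1c(Cc2cc(OC)c(OC)c(OC)c2)nc2c(N)ncnc21`, is compound 3 with but-1-en-1-yl in place of cyclopropyl on a saturated chain carbon bound to an aromatic nitrogen. Among the measured compounds shown here, the only measured step at this place is a 1.9-fold higher number from compound 1 to compound 2 (0.28 log units; within the scatter), a swap of one small group for another that left the number within the scatter. For the measured compounds named here, that is the sole guide here, so no step beyond the scatter is expected from compound 3 to compound 4, in either direction. Compound 4 is therefore estimated at 65000 nM, with a range from 20000 nM to 200000 nM, meaning an expected step of a 1.2-fold lower number from compound 3 to compound 4 (0.07 log units; within the scatter).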

Compound 4, half-maximal inhibitory concentration: 64600 nM
Compound 4: the middle estimate sits 1.0-fold (0.00 log units) above what was measured; measured number inside the range.
By their numbers in this assay, from the lowest: compounds 1, 2, 4 and 3 (each within the scatter of the next, the first and the last beyond it).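

In this assay, putting the open but-1-en-1-yl chain in place of the cyclopropyl ring gives a 1.2-fold lower number from compound 3 to compound 4 (0.07 log units; within the scatter), which lies within the scatter. On a saturated chain carbon bound to an aromatic nitrogen, then, losing this all-carbon ring and gaining a double bond leaves the number essentially unchanged. No available evidence explains this result. From the compounds shown here alone, whether an amine or a carboxylic acid at this place would shift the number beyond the scatter stays open, and the same question applies to a much longer chain.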